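Trimethoxyphenyl in place of fluorophenyl on the chalcone arm

The source may report more compounds than this note shows. Statements on the series, on what has been measured and on what is new or still open speak of the compounds shown alone.

Compound 1 `Cc1ccc(/C=C/C(=O)c2cccc(NC(=O)c3cc(-c4ccncc4)n[nH]3)c2)cc1` gives 69400 nM in a functional assay, read by spectrophotometry, tested at 100 uM (a lower number here means a stronger inhibitor, a higher number a weaker inhibitor), and compound 2 `O=C(/C=C/c1ccc(F)cc1)c1cccc(NC(=O)c2cc(-c3ccncc3)n[nH]2)c1` gives 56000 nM. Compound 2 has the lowest of the two numbers, yet its step of a 1.2-fold lower number from compound 1 to compound 2 (0.09 log units; within the scatter) lies within the scatter, so the two are not distinguished. Compound 3 `COc1cc(/C=C/C(=O)c2cccc(NC(=O)c3cc(-c4ccncc4)n[nH]3)c2)cc(OC)c1OC` differs from compound 2 by 3,4,5-trimethoxyphenyl in place of 4-fluorophenyl on a double-bonded chain carbon bound to a double-bonded chain carbon. Going by the values given here, no measured step touches this change, and the one known step is within the scatter, so for compound 3 an estimate of 50000 nM is made, with a range of 15000 nM to 150000 nM; the expected step of a 1.1-fold lower number from compound 2 to compound 3 (0.05 log units; within the scatter) is therefore taken as none beyond the scatter.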

Compound 3, half-maximal inhibitory concentration: 54500 nM
Beside the measured number, compound 3's estimate is 1.1-fold (0.04 log units) below it; the range from low to high includes it.
By their numbers in this assay, from the lowest: compounds 3, 2 and 1 (each within the scatter of the next).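

In this assay, 3,4,5-trimethoxyphenyl in place of 4-fluorophenyl gives a 1.0-fold lower number from compound 2 to compound 3 (0.01 log units; within the scatter) and, in place of 4-methylphenyl, gives a 1.3-fold lower number from compound 1 to compound 3 (0.10 log units; within the scatter) on the same chain carbon. This position therefore takes a group of 12 heavy atoms with 3 hydrogen-bond acceptors, and the three compounds remain undistinguished. Nothing available explains this lack of separation.

Still open, as far as these compounds go, is whether an amine or a carboxylic acid in place of these phenyl groups would move the number beyond the scatter. A longer chain at this position is equally untested among the compounds shown.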